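Alkyne terminus chain length in an antiproliferative series

A few compounds are considered here, and "the series" means these few. Any claim that something is new, unique, unknown or untested is made for them only; others in the source may bear on it.

Measured so far in a functional assay on CCRF-CEM cells (Homo sapiens) for antiproliferative activity, read by MTT assay, with a stated time of 3 days; a higher number here means a weaker inhibitor, a lower number a stronger inhibitor:
compound 1 `Cc1ccc(C#Cc2cn(C/C=C\CN3C(=O)c4ccccc4C3=O)c(=O)[nH]c2=O)cc1`: 238000 nM
compound 2 `CCCCCCC#Cc1cn(C/C=C/CN2C(=O)c3ccccc3C2=O)c(=O)[nH]c1=O`: 28000 nM
compound 3 `CCCCCC#Cc1cn(C/C=C/CN2C(=O)c3ccccc3C2=O)c(=O)[nH]c1=O`: > 500000 nM, which is a limit of this assay and not a number.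

Compound 1 stands highest of the two numbers given; compound 2 sits lower by a margin beyond the scatter. Compound 4 `CCCCc1ccc(C#Cc2cn(C/C=C\CN3C(=O)c4ccccc4C3=O)c(=O)[nH]c2=O)cc1` differs from compound 1 by propyl in place of hydrogen on a saturated chain carbon bound to an aromatic carbon. Going by the values given here, the one measured step that bears on this is an at least 17-fold higher number from compound 2 to compound 3 (1.25 log units; beyond the scatter), where the chain at the alkyne terminus lost a carbon and the number rose sharply; compound 3 reached only the limit noted in the limit of > 500000 nM in this assay, at which 1 of the 3 values shown sits. Compound 4 adds chain carbons at the alkyne terminus, so the reverse direction is expected: a 7.9-fold lower number from compound 1 to compound 4 (0.90 log units; beyond the scatter). Compound 4 is estimated at 30000 nM, with a range from 8000 nM to 150000 nM.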

Compound 4, half-maximal inhibitory concentration: 23000 nM
Estimate against measurement, compound 4: 1.3-fold (0.12 log units) above; measured number inside the range.
By their numbers in this assay, from the lowest: compounds 4 and 2 (each within the scatter of the next); then compound 1. At a limit, above all of these: compound 3.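

In this assay, lengthening methyl to butyl on the phenyl ring gives a 10-fold lower number from compound 1 to compound 4 (1.01 log units; beyond the scatter), so chain length at the alkyne terminus also matters when a phenyl ring carries the chain. The earlier step covered only open alkyl chains, on compounds with the other double-bond geometry. No measured property accounts for this step.

Open, from the compounds shown here alone, is whether a longer chain than butyl lowers the number further, or whether an amine at the chain end keeps the gain. Also open, going by these compounds, is whether 4-butylphenyl behaves the same with the other double-bond geometry.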